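Swapping cyclohexyl for 2-methoxyethyl on the amine

This account rests on a few compounds, and the source may have more. Where it says the series, first, only, none or still open, it means among the compounds named here.

Measured in a functional assay on HeLa cells (Homo sapiens) for inhibition, with a stated time of 72 h (on this read-out higher numbers stand for an effect only at larger amounts of compound and lower numbers for an effect already at smaller amounts), so far:
- compound 1 `COc1cc(CNC2CCCCC2)ccc1OCc1ccc(Cl)nc1` gives "nd(insoluble)" (no result reported)
- compound 2 `COc1cc(CNCc2ccncc2)ccc1OCc1ccc(Cl)c(Cl)c1` gives 4000 nM
- compound 3 `COc1cc(OCc2ccc(Cl)cc2)ccc1CNCc1ccncc1` gives 440 nM

Compound 1 stands without a single number in this assay, so it offers no measured starting point. The two compounds with numbers sit well apart, and compound 3 reaches its effect at the smaller amount.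

Compound 4 `COCCNCc1ccc(OCc2ccc(Cl)nc2)c(OC)c1` is the next to be read. It keeps the core of compound 1 and places 2-methoxyethyl in place of cyclohexyl on an amine nitrogen. No size or direction of step from compound 1 can be given, since that compound lacks a value. The expectation is instead that compound 4 will land within the span set by compound 3 (440 nM) and compound 2 (4000 nM), toward its upper end, though nothing measured tests this change directly.

For compound 4 the expected value is about 3000 nM, with an estimated range from 500 nM to 18000 nM.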

Compound 4, half-maximal effective concentration: 97000 nM
Compound 4: the middle estimate sits 32-fold (1.51 log units) below what was measured; the measured number lies above the stated range.
By their numbers in this assay, from the lowest: compound 3; then compound 2; then compound 4.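

In this assay, for the compounds shown here, compound 1 carries no single number, so no step from compound 1 to compound 4 can be read. From the compounds shown here alone, what swapping cyclohexyl for 2-methoxyethyl on the amine does to this read-out stays open. Nothing shown accounts for the value of compound 4.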